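The compounds below may be only part of what the source reports. "The series", "measured", "known", "first", "only" and "open" are said of these compounds alone.

Working notes on the series. The core seen in compound 1 `O=C(CSc1nc(Nc2ccccc2)c2ccccc2n1)Nc1cccc(F)c1` carries an aryl group on an amide-type nitrogen; in compound 1 this is 3-fluorophenyl, in compound 2 `CCc1ccc(NC(=O)CSc2nc(Nc3ccccc3)c3ccccc3n2)cc1` it is 4-ethylphenyl. In a functional assay on PC-3 cells (Homo sapiens) for inhibition, read by MTT assay, with a stated time of 72 h (a higher number here means a weaker inhibitor, a lower number a stronger inhibitor), compound 1 gives 15600 nM and compound 2 gives 17900 nM. The step of a 1.1-fold higher number from compound 1 to compound 2 (0.06 log units; within the scatter) lies within the scatter, so on the two numbers shown compound 2 sits level with compound 1, its only neighbour, and neither can be set apart from the other.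

Compound 3 `O=C(CSc1nc(Nc2ccccc2)c2ccccc2n1)Nc1ccc(Cl)cc1Cl` is not yet measured. Its change from compound 2 is 2,4-dichlorophenyl in place of 4-ethylphenyl on an amide-type nitrogen. For the measured compounds named here, only one measured step bears on this position, a 1.1-fold higher number from compound 1 to compound 2 (0.06 log units; within the scatter), and that exchange of one aryl for another at the same place produced no shift beyond the scatter. Going by the values given here, no measured step speaks to chlorine on this ring, so the expectation rests on that single step alone. For compound 3 the expected step in this assay is a 1.1-fold lower number from compound 2 to compound 3 (0.05 log units; within the scatter), which is no movement beyond the scatter. Compound 3 is therefore estimated at 16000 nM, with a range from 6000 nM to 45000 nM.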

Compound 3, half-maximal inhibitory concentration: 9110 nM
For compound 3 the middle estimate is 1.8-fold (0.24 log units) above the measured one, and the stated range covers the measured number.
By their numbers in this assay, from the lowest: compounds 3, 1 and 2 (each within the scatter of the next).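

In this assay, for the compounds shown here, the first chlorine-bearing aryl group at this position gives a 2.0-fold lower number from compound 2 to compound 3 (0.29 log units; within the scatter) and a 1.7-fold lower number from compound 1 to compound 3 (0.23 log units; within the scatter), so compound 3 cannot be set apart from either neighbour. The earlier pair showed only that 3-fluorophenyl and 4-ethylphenyl could not be told apart; with 2,4-dichlorophenyl, three aryl groups on the amide-type nitrogen now stand level, and two chlorines on this ring produce no step beyond the scatter. No measurement bearing on why these aryl exchanges leave the number within the scatter is available.

The compounds shown leave open whether anything on the amide-type nitrogen can move the number beyond the scatter, for instance a ring carrying an amine or a carboxylic acid, or a longer chain in place of the aryl group. As far as these compounds go, they also say nothing about the rest of the structure, since the shared core stays the same in all three compounds, and so the contribution of that part to the activity in this assay remains unknown.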